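Three limits at the top, and a methyl to hydrogen trim

The source may hold more compounds than are shown below. What is called first, only, known or untested is meant among the compounds shown, and "the series" means these compounds.

Measured compounds in a functional assay on CCRF-CEM cells for agonist activity at C-X-C chemokine receptor type 4 (Homo sapiens), read by calcium flux, with a stated time of 25 min; a lower number here means that less compound is needed, a higher number that more compound is needed for the effect:
compound 1 `Cc1cnc(CN(C)C[C@H]2Cc3c(cccc3N3CCNCC3)CN2)c(C)c1`: > 30000 nM
compound 2 `CN(C[C@H]1Cc2c(cccc2N2CCN(C3CC3)CC2)CN1)[C@H]1CCCc2cccnc21`: > 30000 nM
compound 3 `CCN(C[C@H]1Cc2c(cccc2N2CCNCC2)CN1)[C@H]1CCCc2cccnc21`: > 30000 nM

Each of these values is a limit of the assay, not a number. For the measured compounds named here, compound 3 therefore stands at the limit of > 30000 nM in this assay, at which 3 of the 3 values shown sit, together with the other two, and no step between measured compounds can be read from them. Compound 4 `CN(C[C@H]1Cc2c(cccc2N2CCNCC2)CN1)[C@H]1CCCc2cccnc21` differs from compound 3 only by hydrogen in place of methyl on a saturated chain carbon bound to an amine nitrogen, which read one bond further out is ethyl to methyl. With every measured value sitting at the limit, no change beyond the usual scatter is expected for the step of a number no higher from compound 3 to compound 4 (the limit leaves the size open). Compound 4 is accordingly estimated to give 30000 nM, within 10000 nM to 100000 nM, most likely again as a limit.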

Compound 4, half-maximal effective concentration: > 30000 nM
Compound 4 was reported as a limit; the forecaster's own chance of this, stated with the estimate: 80%; the middle value lies on the limit itself.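

For the compounds shown here, compound 4 gives only a limit in this assay, > 30000 nM, so no step to it from compound 2 or compound 3 can be read. The compounds shown leave open which change, if any, would give a measurable value.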